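This account rests on a few compounds, and the source may have more. Where it says the series, first, only, none or still open, it means among the compounds named here.

Measured in a physicochemical assay for solubility, read by spectrophotometry, in phosphate buffer, with a stated time of 18 h, at pH 7.4; a lower number here means a less soluble compound, a higher number a more soluble compound:
- compound 1 `CCc1ccc(-c2nc3c(c(C)nn3-c3ccccc3)c(-c3ccccc3C(F)(F)F)c2C#N)cc1`: 11000 nM
- compound 2 `Cc1ccc(-c2nc3c(c(C)nn3-c3ccccc3)c(-c3ccccc3O)c2C#N)cc1`: 26000 nM
- compound 3 `Cc1nn(-c2ccccc2)c2nc(-c3ccc(C(C)C)cc3)c(C#N)c(-c3ccccc3O)c12`: 9800 nM

Compound 3 lies within the scatter of compound 1, and compound 2 is the value furthest from it. The next compound to be read is compound 4 `Cc1nn(-c2ccccc2)c2nc(-c3ccc(F)cc3)c(C#N)c(-c3ccccc3O)c12`, and the change is fluoro in place of isopropyl on an aromatic carbon, para to a large group: fluoro in place of isopropyl on an aromatic carbon.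

Among the measured compounds shown here, one measured step bears on this: a 2.7-fold lower number from compound 2 to compound 3 (0.42 log units; beyond the scatter), isopropyl in place of methyl on an aromatic carbon, which is modest. For the measured compounds named here, compound 1 is joined to the others by no step that differs in one place, so it adds nothing here. Going by the values given here, no measured step has fluoro entering, so the reading across rests on isopropyl leaving, the reverse of the step that entered it.

A modest rise of similar size is therefore expected in this assay, estimated as a 2.0-fold higher number from compound 3 to compound 4 (0.31 log units; beyond the scatter). With a single step as support, the range is kept wide. The estimated value for compound 4 is 20000 nM, with an expected range of 9000 nM to 45000 nM.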

Compound 4, solubility: 6000 nM
For compound 4 the middle estimate is 3.3-fold (0.52 log units) above the measured one, outside the stated range (below it).
By their numbers in this assay, from the lowest: compounds 4, 3 and 1 (each within the scatter of the next); then compound 2.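

In this assay, the exchange of 4-isopropylphenyl for 4-fluorophenyl gives a 1.6-fold lower number from compound 3 to compound 4 (0.21 log units; within the scatter), so on this aromatic carbon, para to a large group, fluoro in place of isopropyl does not separate the two compounds, even though the entering group has fewer heavy atoms. The comparison with the methyl compound gives a 4.3-fold lower number from compound 2 to compound 4 (0.64 log units; beyond the scatter), which leaves compound 2 apart from both compound 3 and compound 4, and the methyl-to-isopropyl step therefore does not carry over to fluoro as a simple trend with group size. No measurement in hand accounts for compound 2 standing apart.

On these data alone, it remains open whether a methoxy group, an amine or a carboxylic acid on this carbon would fall with compound 2 or with compound 3 and compound 4. Compound 1 differs from the others in more than one place, so the effect of trifluoromethyl in place of the hydroxyl group also stays unresolved.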